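This account rests on a few compounds, and the source may have more. Where it says the series, first, only, none or still open, it means among the compounds named here.

Of the compounds shown here, three that share one core have been measured in a functional assay on LoVo cells (Homo sapiens) for inhibition, read by MTT assay, with a stated time of 24 h; a lower number here means a stronger inhibitor, a higher number a weaker inhibitor. Compound 1 `CC1(C)[C@H]2CC[C@]1(C)N(Cc1cn(-c3cccc(F)c3)nn1)C(=O)C2` gives 90 nM, compound 2 `CC1(C)[C@H]2CC[C@]1(C)N(Cc1cn(-c3ccccc3C#N)nn1)C(=O)C2` gives 140 nM, and compound 3 `COc1ccccc1-n1cc(CN2C(=O)C[C@@H]3CC[C@@]2(C)C3(C)C)nn1` gives 70 nM. Compound 2 carries the highest of the three numbers, yet both neighbours sit close to it: a 1.6-fold higher number from compound 1 to compound 2 (0.19 log units; within the scatter) and a 2.0-fold lower number from compound 2 to compound 3 (0.30 log units; within the scatter), so the three cannot be told apart with confidence.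

Compound 4 `COc1ccc(-n2cc(CN3C(=O)C[C@@H]4CC[C@@]3(C)C4(C)C)nn2)cc1` has not yet been measured. Its change from compound 2 is 4-methoxyphenyl in place of 2-cyanophenyl on an aromatic nitrogen. For the measured compounds named here, two measured steps bear on this. a 2.0-fold lower number from compound 2 to compound 3 (0.30 log units; within the scatter) exchanges the same two groups, though there the methoxy sits as 2-methoxyphenyl rather than 4-methoxyphenyl. a 1.3-fold lower number from compound 1 to compound 3 (0.11 log units; within the scatter) shows that swapping one substituted phenyl for another on this aromatic nitrogen also stayed within the scatter. Nothing among these compounds points to a step beyond the scatter. Compound 4 is therefore expected to show a 1.6-fold lower number from compound 2 to compound 4 (0.19 log units; within the scatter), a drift that itself stays within the scatter. The estimate for compound 4 is 90 nM, with a range from 40 nM to 200 nM.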

Compound 4, half-maximal inhibitory concentration: 70 nM
For compound 4 the middle estimate is 1.3-fold (0.11 log units) above the measured one; low and high end bracket the measured number.
By their numbers in this assay, from the lowest: compounds 3, 4, 1 and 2 (each within the scatter of the next).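

In this assay the exchange of 2-methoxyphenyl for 4-methoxyphenyl on this aromatic nitrogen gives no change at the digits printed from compound 3 to compound 4 (within the scatter) and so these two methoxy-bearing groups cannot be told apart. Starting from the other two groups, the same 4-methoxyphenyl gives a 2.0-fold lower number from compound 2 to compound 4 (0.30 log units; within the scatter) and a 1.3-fold lower number from compound 1 to compound 4 (0.11 log units; within the scatter) so it cannot be separated from 2-cyanophenyl or 3-fluorophenyl either. All four substituted phenyl groups at this position therefore sit together, with no step beyond the scatter among them.

Still open, on these data alone, is whether the number would hold with a carboxylic acid or an amine on the phenyl ring, or with a longer alkyl chain in place of the ring. No measurement shown gives a reason for this flat picture.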